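The compounds below may be only part of what the source reports. "The series", "measured", "known", "first", "only" and "open" are said of these compounds alone.

Among the compounds with values here, in a functional assay on DU-145 cells (Homo sapiens) for cytotoxicity, read by trypan blue exclusion, with a stated time of 96 h (on this read-out higher numbers stand for weaker inhibition and lower numbers for stronger inhibition), compound 3 `COc1cc(OC)c(/C=C/S(=O)(=O)Cc2ccc(OC)c(NC(F)(F)C(=O)O)c2)c(OC)c1` gives 150 nM, the lowest number so far, while compound 1 `COC(=O)C(Nc1cc(CS(=O)(=O)/C=C/c2c(OC)cc(OC)cc2OC)ccc1OC)c1ccc(Cl)cc1` gives 400 nM and compound 2 `COc1cc(OC)c(/C=C/S(=O)(=O)Cc2ccc(OC)c(NCCC(=O)O)c2)c(OC)c1` gives 5000 nM. Compound 4 `COc1cc(OC)c(/C=C/S(=O)(=O)Cc2ccc(OC)c(NC(C(=O)O)c3ccc(Br)cc3)c2)c(OC)c1` carries (4-bromophenyl)(carboxy)methyl in place of carboxy(difluoro)methyl on a nitrogen on an aromatic ring. The nearest guide is the modest step of a 2.7-fold lower number from compound 1 to compound 3 (0.43 log units; beyond the scatter), where the group that leaves, (4-chlorophenyl)(methoxycarbonyl)methyl, most resembles the one entering here. The large steps of a 33-fold lower number from compound 2 to compound 3 (1.52 log units; beyond the scatter) and a 13-fold higher number from compound 1 to compound 2 (1.10 log units; beyond the scatter) show that changes at this nitrogen can move the number widely. A modest rise is therefore expected, a 2.3-fold higher number from compound 3 to compound 4 (0.37 log units; beyond the scatter). For compound 4 the estimate is 350 nM, with an expected range of 80 nM to 1500 nM.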

Compound 4, half-maximal inhibitory concentration: 300 nM
Beside the measured number, compound 4's estimate is 1.2-fold (0.07 log units) above it, within the range that was stated.
By their numbers in this assay, from the lowest: compounds 3, 4 and 1 (each within the scatter of the next, the first and the last beyond it); then compound 2.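

In this assay the much larger (4-bromophenyl)(carboxy)methyl group on this nitrogen reads the same as carboxy(difluoro)methyl within the scatter, with a 2.0-fold higher number from compound 3 to compound 4 (0.30 log units; within the scatter). It also cannot be told apart from the ester-bearing (4-chlorophenyl)(methoxycarbonyl)methyl group, with a 1.3-fold lower number from compound 1 to compound 4 (0.12 log units; within the scatter). Compound 2, with its 2-carboxyethyl group, stays clearly apart, with a 17-fold lower number from compound 2 to compound 4 (1.22 log units; beyond the scatter). Nothing measured here explains these numbers. The compounds shown leave open how an amide in place of the carboxylic acid, or chlorine in place of the bromine with the acid kept, would read.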